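The source may hold more compounds than are shown below. What is called first, only, known or untested is meant among the compounds shown, and "the series" means these compounds.

Compound 1, `CCCCCNc1cnc(C(=O)NCc2ccccc2)cn1`. In an ADME assay on Vero cells (Chlorocebus sabaeus) for cytotoxicity, read by microscopy, with a stated time of 6 days (on this read-out higher numbers stand for lower toxicity in this test and lower numbers for higher toxicity in this test), compound 1 gives > 100000 nM, which is a limit of the assay and not a number.
Compound 2, `CCCCCCCNc1cnc(C(=O)NCc2ccccc2)cn1`. In this assay compound 2 gives >= 100000 nM, again a limit.
Compound 3, `CCCCCCCCNc1nccnc1C(=O)NCc1ccccc1`. In this assay compound 3 gives > 100000 nM, also a limit.

Compound 2 therefore stands at a limit, not at a measured number, and all three values sit at the top edge of the test: two at the limit of > 100000 nM in this assay, at which 2 of the 3 values shown sit, and one at the limit of >= 100000 nM in this assay, at which 1 of the 3 values shown sits. Among the measured compounds shown here, the only step between these compounds that differ in one place, a step that the two limits leave unreadable from compound 1 to compound 2, cannot be read, because both ends are limits.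

Compound 4, `CCCCCCNc1cnc(C(=O)NCc2ccccc2)cn1`, differs from compound 2 in one place: hydrogen in place of methyl on a saturated chain carbon, six bonds along the chain from a nitrogen on an aromatic ring. This is the same kind of small change to the chain as the step from compound 1 to compound 2, which showed no readable effect, and no measured value in this set points in any direction. No step beyond the usual scatter is therefore expected from compound 2 to compound 4, a number no higher from compound 2 to compound 4 (the limit leaves the size open). Compound 4 is estimated at 100000 nM, within 50000 nM to 200000 nM, and most likely again reported only as a limit.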

Compound 4, minimum cytotoxic concentration: >= 100000 nM
Compound 4: a limit, no number (the forecaster's own chance of this, stated with the estimate: 85%); the middle value sits exactly at the limit.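

Compound 4 gives >= 100000 nM, a limit of the assay and not a number. The steps from compound 2 to compound 4 and from compound 1 to compound 4 cannot be read. The compounds shown leave open whether the length of the chain affects the minimum cytotoxic concentration at all in this assay.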